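Trimming the amide substituent from cyclopentyl to methyl

The source may report more compounds than this note shows. Statements on the series, on what has been measured and on what is new or still open speak of the compounds shown alone.

Of the compounds shown here, three share a core and have been tested in a functional assay on K562 cells (Homo sapiens) for antiproliferative activity, read by CCK-8 assay, with a stated time of 72 h; on this read-out higher numbers stand for weaker inhibition of growth and lower numbers for stronger inhibition of growth. Compound 1 `CCC1C(=O)N(C)c2cnc(Nc3ccc(S(=O)(=O)NCC(C)C)cc3)nc2N1c1ccn(C)n1` gives 7300 nM in this assay. Compound 2 `CC[C@@H]1C(=O)N(C)c2cnc(-n3ccc4cc(C(=O)NCC(C)C)ccc43)nc2N1C1CCCC1` gives 638 nM. Compound 3 `CC[C@@H]1C(=O)N(C)c2cnc(-n3ccc4cc(C(=O)NC5CCCC5)ccc43)nc2N1C1CCCC1` gives 414 nM, the lowest number among the three, although the step of a 1.5-fold lower number from compound 2 to compound 3 (0.19 log units; within the scatter) is within the scatter and only compound 1 stands clearly apart.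

Compound 4 `CC[C@@H]1C(=O)N(C)c2cnc(-n3ccc4cc(C(=O)NC)ccc43)nc2N1C1CCCC1` is not yet measured. It differs from compound 3 by methyl in place of cyclopentyl on an amide-type nitrogen. Within the data shown here, the only measured step at this position, a 1.5-fold lower number from compound 2 to compound 3 (0.19 log units; within the scatter), shows that exchanging one modest alkyl group for another at the amide nitrogen changed the number by less than the scatter. Going to methyl removes far more bulk than that step tested, so no direct precedent exists, and the expectation is an increase of the number that may or may not exceed the scatter: the step from compound 3 to compound 4 is estimated at a 1.8-fold higher number from compound 3 to compound 4 (0.26 log units; within the scatter). Compound 4 is therefore expected to give about 750 nM in this assay, within a range from 300 nM to 1900 nM.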

Compound 4, concentration for 50% growth inhibition: 705 nM
Compound 4: middle estimate off by 1.1-fold (0.03 log units), on the high side; measured number inside the range.
By their numbers in this assay, from the lowest: compounds 3, 2 and 4 (each within the scatter of the next); then compound 1.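

With methyl on the amide-type nitrogen, this position has now been read from a single carbon up to a cyclopentyl ring, a much wider span than the earlier comparison of isobutyl and cyclopentyl. In this assay, the change from the ring gives a 1.7-fold higher number from compound 3 to compound 4 (0.23 log units; within the scatter) and the shortening of the isobutyl chain gives a 1.1-fold higher number from compound 2 to compound 4 (0.04 log units; within the scatter); neither step leaves the scatter, so all three alkyl groups sit at one level on this read-out. Nothing measured here offers any explanation for that flatness.

From the compounds shown here alone, whether the level holds for a chain ending in an amine or a carboxylic acid, or for a phenyl ring on this nitrogen, stays open. Going by these compounds, it is also open whether the plain primary amide, with hydrogen in place of methyl, keeps the number at this level.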